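Bromo in Place of Chloro: A Small Step Repeated

A few compounds are considered here, and "the series" means these few. Any claim that something is new, unique, unknown or untested is made for them only; others in the source may bear on it.

Three compounds have been measured in a functional assay on Jurkat cells (Homo sapiens) for cytotoxicity, read by luminescence and CellTiter-Glo, with a stated time of 3 days; on this read-out higher numbers stand for weaker inhibition and lower numbers for stronger inhibition:
compound 1 `O=C(Nc1ccc(C(F)(F)F)cc1)c1cc(Cl)c(-c2ccccc2)cc1O` gives 1160 nM;
compound 2 `O=C(Nc1ccc(Cl)c(Cl)c1)c1cc(F)ccc1O` gives 670 nM;
compound 3 `O=C(Nc1ccc(C(F)(F)F)cc1)c1cc(Br)c(-c2ccccc2)cc1O` gives 740 nM.

Compound 3 differs from compound 1 by one change, (bromo in place of chloro on an aromatic carbon), and this change gave a 1.6-fold lower number from compound 1 to compound 3 (0.20 log units; within the scatter). Compound 4 `O=C(Nc1ccc(Br)c(Cl)c1)c1cc(F)ccc1O` has not yet been measured; it differs from compound 2 by bromo in place of chloro on an aromatic carbon. The difference between the cores of compound 1 and compound 2 is not broken down here. The two changes are the same kind of change, not the same: in compound 1 the place is ortho to a phenyl group, meta to a large group and para to a hydroxy group, while in compound 2 it is ortho to a chloro group and para to a large group. The expected step, resting on compound 3 having given 740 nM after the same kind of change, is a 1.2-fold lower number from compound 2 to compound 4 (0.09 log units; within the scatter) in this assay. Because a 1.6-fold lower number from compound 1 to compound 3 (0.20 log units; within the scatter) lay within the scatter, compound 4 is estimated at 550 nM, between 250 nM and 1200 nM.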

Compound 4, half-maximal inhibitory concentration: 860 nM
Compound 4: middle estimate off by 1.6-fold (0.19 log units), on the low side, within the range that was stated.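

In this assay, bromo in place of chloro on this second core gave a 1.3-fold higher number from compound 2 to compound 4 (0.11 log units; within the scatter). Set beside the earlier step, the two cannot be told apart: the same change on two cores in this assay, a 1.6-fold lower number (0.20 log units; within the scatter) from compound 1 to compound 3 and a 1.3-fold higher number (0.11 log units; within the scatter) from compound 2 to compound 4, 2.0-fold (0.30 log units) apart, within the scatter of two such steps. So on both cores this swap moved the number by no more than repeated measurement would, but two such small steps cannot show whether the change truly behaves alike on the two cores, and a modest real difference could be hidden in the scatter.

The compounds shown leave open what happens when the chloro group gives way to something other than bromo, such as a nitrile or an amine. They also leave open whether the step stays this small on a third core.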